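A few compounds are considered here, and "the series" means these few. Any claim that something is new, unique, unknown or untested is made for them only; others in the source may bear on it.

Measured in a functional assay (Homo sapiens) for inhibition; on this read-out higher numbers stand for weaker inhibition and lower numbers for stronger inhibition:
- compound 1 `COc1cc(/C=C/C(=O)c2ccccc2[N+](=O)[O-])cc(OC)c1`: 3700 nM
- compound 2 `CCCCOc1cccc(C(=O)/C=C/c2ccc(OC)cc2OC)c1`: 65000 nM
- compound 3 `COc1cc(/C=C/C(=O)c2ccc(C3CCCCC3)cc2)cc(OC)c1`: 39000 nM

Compound 1 holds the lowest number of the three, so it shows the strongest inhibition in this assay. Compound 2 and compound 3 both lie well beyond the scatter above it.

The next compound to be tested is compound 4 `COc1cc(/C=C/C(=O)c2ccccc2O)cc(OC)c1`. It keeps the core of compound 1 but carries hydroxy in place of nitro on an aromatic carbon, ortho to a large group: hydroxy in place of nitro on an aromatic carbon.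

For the measured compounds named here, no two measured compounds differ in only one place, so nothing here directly shows what such a swap does. Compound 1, at 3700 nM, is the lowest of a very small set, so a move toward higher numbers seems more likely than a further drop. A step of moderate size toward weaker inhibition is therefore expected, though with wide uncertainty. The expected change is a 2.7-fold higher number from compound 1 to compound 4 (0.43 log units; beyond the scatter). For compound 4 the estimated value is 10000 nM, within an expected range from 2500 nM to 40000 nM.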

Compound 4, half-maximal inhibitory concentration: 8100 nM
Compound 4: middle estimate off by 1.2-fold (0.09 log units), on the high side; the range from low to high includes it.
By their numbers in this assay, from the lowest: compound 1; then compound 4; then compounds 3 and 2 (each within the scatter of the next).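

This first single-place comparison shows that in this assay, hydroxy in place of nitro on an aromatic carbon, ortho to a large group, gives a 2.2-fold higher number from compound 1 to compound 4 (0.34 log units; beyond the scatter) and so weakens inhibition modestly. Inhibition therefore does not depend on nitro alone at this position, since compound 4 still inhibits with hydroxy there, although compound 1 remains the stronger of the two. No measurement here accounts for the size of this step.

Going by these compounds, whether an amine or a carboxylic acid at the same position would restore inhibition, weaken it further, or fall between compound 1 and compound 4 remains open. A single pair also leaves open whether this swap would give a similar step with other groups on the core of compound 1.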